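Urea series: tert-butyl replaces trifluoromethyl at the aryl position

The source may report more compounds than this note shows. Statements on the series, on what has been measured and on what is new or still open speak of the compounds shown alone.

Three measured compounds share one core. Compound 1 `CN(C)CC[C@H](NC(=O)c1ccc2ccccc2c1)c1ccc(Cl)cc1` gives 109% in an assay on NIH3T3 cells with Urotensin-2 receptor (Homo sapiens) as the target; a lower number here means a smaller maximal response, a higher number a larger maximal response. Compound 2 `Cc1cccc(Cl)c1C(=O)NC(CCN(C)C)c1ccc(Cl)cc1` gives 105% in this assay. Compound 3 `CN(C)CCC(NC(=O)Nc1ccc(C(F)(F)F)cc1)c1ccc(Cl)cc1` gives 105% in this assay. Compound 3 is level with compound 2 at the digits given, and its gap to compound 1 lies within the usual scatter, so the three numbers read as one plateau of near-full maximal response.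

Compound 4 `CN(C)CCC(NC(=O)Nc1ccc(C(C)(C)C)cc1)c1ccc(Cl)cc1` is not yet measured. Relative to compound 3 the change is tert-butyl in place of trifluoromethyl on an aromatic carbon. Going by the values given here, no pair among the measured compounds differs in only one place, so no single step can be read off. The three values in this assay sit close together despite wider differences in the amide or urea part, and the change in compound 4 keeps a substituent at the same place on the ring. In this assay the expected step is a number 1 percentage points lower from compound 3 to compound 4 (within the scatter), that is none beyond the scatter. For compound 4 the estimate in this assay is 104%, from 90% to 118%.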

Compound 4, largest response reached (reported as efficacy), in percent of the reference or control that the assay uses: 103%
Beside the measured number, compound 4's estimate is 1 percentage points above it; measured number inside the range.
By their numbers in this assay, from the lowest: compounds 4, 2, 3 and 1 (each within the scatter of the next).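

Going by these compounds alone, this is the first comparison that differs in one place only: with tert-butyl in place of trifluoromethyl on an aromatic carbon, this assay gives a number 2 percentage points lower from compound 3 to compound 4 (within the scatter), and that step does not separate the two groups. Within this pair, the maximal response therefore tolerates an exchange of fluorine atoms for carbon atoms at an unchanged count of heavy atoms. No available measurement offers an explanation for this result.

As far as these compounds go, both groups have no hydrogen-bond donors or acceptors and no net charge, so it remains open whether a carboxylic acid or an amine at this place would hold the response at the same level. The read-out also covers only the largest response reached, leaving open how much compound is needed to reach it.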